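Amino for chloro on a fused core: expected shift in cytotoxicity

The source may hold more compounds than are shown below. What is called first, only, known or untested is meant among the compounds shown, and "the series" means these compounds.

The measured compounds:
compound 1, `Nc1nc(Cl)c2ncn(Cc3ccc(CCl)cc3)c2n1`: 53700 nM
compound 2, `ClCc1cccc(Cn2cnc3c(Cl)nc(Cl)nc32)c1`: 6450 nM
compound 3, `ClCc1ccc(Cn2cnc3c(Cl)nc(Cl)nc32)cc1`: 9330 nM

In a functional assay on UACC-62 cells (Homo sapiens) for cytotoxicity, read by sulforhodamine B assay, with a stated time of 48 h (a lower number here means that less compound is tolerated, a higher number that more compound is tolerated), compound 3 gives 9330 nM, and compound 1 gives 53700 nM. The change from compound 3 to compound 1 is amino in place of chloro on an aromatic carbon, and it produced a 5.8-fold higher number from compound 3 to compound 1 (0.76 log units; beyond the scatter). Compound 2 and compound 3 are built from the same atoms joined differently; the difference between the two cores is not broken down here, and their values lie within the usual scatter of each other.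

Compound 4, `Nc1nc(Cl)c2ncn(Cc3cccc(CCl)c3)c2n1`, has not been measured in this assay. It differs from compound 2 by amino in place of chloro on an aromatic carbon, the same change as that from compound 3 to compound 1. Resting on that single measured step, compound 4 is expected to show a 5.4-fold higher number from compound 2 to compound 4 (0.73 log units; beyond the scatter). The estimate for compound 4 is therefore 35000 nM, with a range from 12000 nM to 90000 nM.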

Compound 4, concentration lethal to 50% of the cells: 13500 nM
For compound 4 the middle estimate is 2.6-fold (0.41 log units) above the measured one; the range from low to high includes it.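

In this assay, amino in place of chloro on a second core gives a 2.1-fold higher number from compound 2 to compound 4 (0.32 log units; beyond the scatter). The direction of the change carries over from one core to the other, but its size does not: the same change on two cores in this assay, a 5.8-fold higher number (0.76 log units; beyond the scatter) from compound 3 to compound 1 and a 2.1-fold higher number (0.32 log units; beyond the scatter) from compound 2 to compound 4, 2.7-fold (0.44 log units) apart, beyond the scatter of two such steps. Among the compounds shown here, with only two pairs, this shows that the size of the step cannot simply be transferred between these cores, but it does not show why the steps differ or what size a further core would give.

The compounds shown leave open whether a methylamino or methoxy group on the same aromatic carbon would follow the amino group. They also leave open whether the two steps would still differ if a hydroxymethyl group replaced the chloromethyl group.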